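This account rests on a few compounds, and the source may have more. Where it says the series, first, only, none or still open, it means among the compounds named here.

Measured so far: compound 1 `Cc1cc(C)cc(NC(=O)CN2CCC(c3cccc[n+]3[O-])CC2)c1` gives 52 nM; compound 2 `Cc1ccc(Cl)cc1NC(=O)CN1CCC(c2cccc[n+]2[O-])CC1` gives 126 nM.

In a functional assay on HEK293 cells for agonist activity at D(4) dopamine receptor (Homo sapiens), read by FLIPR (a lower number here means that less compound is needed, a higher number that more compound is needed for the effect), compound 2 stands highest of the two numbers; its nearest neighbour is compound 1, and the step of a 2.4-fold higher number from compound 1 to compound 2 (0.38 log units; beyond the scatter) is the only measured one in the series. Compound 3 `Cc1cccc(C)c1NC(=O)CN1CCC(c2cccc[n+]2[O-])CC1` differs from compound 2 by 2,6-dimethylphenyl in place of 5-chloro-2-methylphenyl on an amide-type nitrogen. Among the measured compounds shown here, the one measured step bears on it only loosely, as it also exchanged the substitution pattern on the same phenyl and was modest in size. A return toward the dimethyl pattern of compound 1 is expected to give compound 3 a number near or somewhat below compound 2, roughly a 1.7-fold lower number from compound 2 to compound 3 (0.23 log units; within the scatter), so compound 3 is estimated at 75 nM, with a range from 25 nM to 220 nM.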

Compound 3, half-maximal effective concentration: 346 nM
Compound 3: the middle estimate sits 4.6-fold (0.66 log units) below what was measured; the measured number lies above the stated range.
By their numbers in this assay, from the lowest: compound 1; then compound 2; then compound 3.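

In this assay, among the compounds shown here, the two dimethylphenyl groups on the amide-type nitrogen are not interchangeable: 2,6-dimethylphenyl gives the highest number so far (a 6.7-fold higher number from compound 1 to compound 3 (0.82 log units; beyond the scatter)). Replacing chlorine-bearing 5-chloro-2-methylphenyl with it also raises the number (a 2.7-fold higher number from compound 2 to compound 3 (0.44 log units; beyond the scatter)), so a dimethyl pattern alone does not restore the lower number of compound 1. Nothing available explains this order. As far as these compounds go, whether an unsubstituted phenyl or a methoxyphenyl at this place would fall below or above compound 1 stays open.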